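Methyl on the Aniline Ring of an Arylidene Cyclohexanone

The source may report more compounds than this note shows. Statements on the series, on what has been measured and on what is new or still open speak of the compounds shown alone.

Compound 1 `Cc1ccc(/C=C2\CCCC(CN(C)c3ccccc3)C2=O)cc1` gives 39.5% in a functional assay on the whole organism (Ear, strain Kunming) for inhibition, with Mus musculus as the target, with stated times of 1 h and 30 min, at a dose of 200 mg/kg by the oral route; on this read-out lower numbers stand for less inhibition and higher numbers for more inhibition at the one dose given (going by the name of the read-out). Compound 2 `Cc1ccc(/C=C2\CCCC(CN(C)c3cccc(C)c3)C2=O)cc1` gives 35.4% in this assay; it carries methyl in place of hydrogen on an aromatic carbon, and the step is a number 4.1 percentage points lower from compound 1 to compound 2 (within the scatter). Compound 3 `CN(CC1CCC/C(=C\c2ccc(S(C)(=O)=O)cc2)C1=O)c1ccccc1` gives 46.9% in this assay; its core differs from that of compound 1 by methylsulfonyl in place of methyl on an aromatic carbon, with the step of a number 7.4 percentage points higher from compound 1 to compound 3 (within the scatter). Compound 4 `Cc1ccc(N(C)CC2CCC/C(=C\c3ccc(S(C)(=O)=O)cc3)C2=O)cc1` is not yet measured; it differs from compound 3 by methyl in place of hydrogen on an aromatic carbon. This is the same kind of change as that between compound 1 and compound 2, but there the methyl sits meta to a large group, whereas here it sits para to a large group. Because the earlier step of a number 4.1 percentage points lower from compound 1 to compound 2 (within the scatter) lay within the scatter, a similarly small step a number 3.9 percentage points lower from compound 3 to compound 4 (within the scatter) is expected. Compound 4 is therefore expected to give 43% in this assay, between 30% and 56%.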

Compound 4, a percentage reported as inhibition, in the whole organism at one dose (the size of the read-out at that dose, not a potency): 27%
Compound 4: middle estimate off by 16 percentage points, on the high side; measured number outside the range, below it.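

With methyl in place of hydrogen on the phenyl of the methyl(phenyl)amino group, this assay gives a step of a number 19.9 percentage points lower from compound 3 to compound 4 (beyond the scatter), so the change does not carry over unchanged between the two cores: the same change on two cores in this assay, a number 4.1 percentage points lower (within the scatter) from compound 1 to compound 2 and a number 19.9 percentage points lower (beyond the scatter) from compound 3 to compound 4, 15.8 percentage points apart, beyond the scatter of two such steps

This does not show why the steps part, since the cores differ by methyl against methylsulfonyl and the added methyl also sits in a different place, para to a large group in compound 4 but not in compound 2. With one pair per core, these two differences cannot be told apart.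

As far as these compounds go, it remains open whether a methyl in the same place on both cores would give matching steps. From the compounds shown here alone, how a chlorine, a methoxy or a carboxylic acid in that place would read also remains open.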